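Solubility across three aryl variants on a shared core

A few compounds are considered here, and "the series" means these few. Any claim that something is new, unique, unknown or untested is made for them only; others in the source may bear on it.

Compound 1 `COC(=O)c1cccc(-c2cnc3[nH]cc(-c4ccccc4)c3c2)c1` gives 4400 nM in a physicochemical assay for solubility, read by HPLC, using the shake flask method; on this read-out higher numbers stand for higher solubility and lower numbers for lower solubility.
Compound 2 `COC(=O)c1cccc(-c2cnc3[nH]cc(-c4cccnc4)c3c2)c1` gives 4300 nM.
Compound 3 `COC(=O)c1cccc(-c2cnc3[nH]cc(-c4cccc(OC)c4)c3c2)c1` gives 2000 nM.

Compound 3 stands lowest of the three in this assay, sitting beyond the scatter below both compound 1 and compound 2. Compound 4 `COC(=O)c1cccc(-c2cnc3[nH]cc(-c4ccncc4)c3c2)c1` differs from compound 3 in one place: pyridin-4-yl in place of 3-methoxyphenyl on an aromatic carbon. Among the compounds with values here, two measured steps bear on it. The step of a 2.2-fold lower number from compound 2 to compound 3 (0.33 log units; beyond the scatter) runs in the opposite direction to this change, and the step of a 1.0-fold lower number from compound 1 to compound 2 (0.01 log units; within the scatter) shows that exchanging phenyl for pyridin-3-yl left the number essentially unchanged. Reversing the loss seen on going to the 3-methoxyphenyl compound, a modest rise is expected, a 2.2-fold higher number from compound 3 to compound 4 (0.33 log units; beyond the scatter). Compound 4 is therefore estimated at 4300 nM, with a range from 2500 nM to 7500 nM.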

Compound 4, solubility: 34000 nM
Compound 4: middle estimate off by 7.9-fold (0.90 log units), on the low side; measured number outside the range, above it.
By their numbers in this assay, from the lowest: compound 3; then compounds 2 and 1 (each within the scatter of the next); then compound 4.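

At this position on the five-membered aromatic ring, pyridin-4-yl behaves unlike the earlier aryl groups in this assay, giving a 17-fold higher number from compound 3 to compound 4 (1.23 log units; beyond the scatter), a 7.9-fold higher number from compound 2 to compound 4 (0.90 log units; beyond the scatter) and a 7.7-fold higher number from compound 1 to compound 4 (0.89 log units; beyond the scatter). The earlier compounds shown here showed no such rise, with pyridin-3-yl and phenyl within the scatter of each other, so a pyridine ring alone does not bring it here. Nothing available explains this difference.

From the compounds shown here alone, whether pyridin-2-yl would read like pyridin-4-yl or like pyridin-3-yl remains open. So does whether the rise would persist with an amine or a carboxylic acid on the ring at this position.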